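A few compounds are considered here, and "the series" means these few. Any claim that something is new, unique, unknown or untested is made for them only; others in the source may bear on it.

Compound 1, `CC1(C)[C@H]2CC[C@]1(C)N(Cc1cn(-c3cccc(Cl)c3)nn1)C(=O)C2`, is the reference point. In a functional assay on HepG2 cells (Homo sapiens) for inhibition, read by MTT assay, with a stated time of 24 h (a higher number here means a weaker inhibitor, a lower number a stronger inhibitor), compound 1 gives 60 nM, the lowest of the three numbers in hand. Its two companions carry other aryl groups on the same aromatic nitrogen: compound 2, `CC1(C)[C@H]2CC[C@]1(C)N(Cc1cn(-c3ccccc3C#N)nn1)C(=O)C2`, gives 180 nM in this assay, and compound 3, `CC1(C)[C@H]2CC[C@]1(C)N(Cc1cn(-c3ccc(Br)cc3)nn1)C(=O)C2`, gives 110 nM. The step of a 3.0-fold higher number from compound 1 to compound 2 (0.48 log units; beyond the scatter) is modest and beyond the scatter, whereas a 1.8-fold higher number from compound 1 to compound 3 (0.26 log units; within the scatter) stays within it, as does a 1.6-fold lower number from compound 2 to compound 3 (0.21 log units; within the scatter).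

Compound 4, `CC1(C)[C@H]2CC[C@]1(C)N(Cc1cn(-c3ccc(O)cc3)nn1)C(=O)C2`, differs from compound 1 in one place: 4-hydroxyphenyl in place of 3-chlorophenyl on an aromatic nitrogen. Among the compounds with values here, none of the measured steps places a hydroxyl on that ring, so no step bears on this change directly. What the measured steps do show is that exchanging the aryl group has so far moved the number either within the scatter or by a modest amount toward a weaker inhibitor, never toward a stronger one. On that basis a step of similar size, toward a higher number, is what is expected in this assay, a 2.5-fold higher number from compound 1 to compound 4 (0.40 log units; beyond the scatter). Compound 4 is therefore estimated at 150 nM in this assay, with a likely range from 60 nM to 400 nM.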

Compound 4, half-maximal inhibitory concentration: 80 nM
Compound 4: the middle estimate sits 1.9-fold (0.27 log units) above what was measured; the measured number falls inside the stated range.
By their numbers in this assay, from the lowest: compounds 1, 4, 3 and 2 (each within the scatter of the next, the first and the last beyond it).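

In this assay the 4-hydroxyphenyl group stands in for 3-chlorophenyl on the aromatic nitrogen with a 1.3-fold higher number from compound 1 to compound 4 (0.12 log units; within the scatter), and for the bromo group on the aromatic carbon with a 1.4-fold lower number from compound 3 to compound 4 (0.14 log units; within the scatter), so an aryl group carrying 1 hydrogen-bond donor and 1 hydrogen-bond acceptor is not separated by these numbers from 3-chlorophenyl, which carries neither, or from 4-bromophenyl. The same change set against the nitrile-bearing ring gives a 2.3-fold lower number from compound 2 to compound 4 (0.35 log units; beyond the scatter), a modest step, so compound 2 stands apart from compound 4 as well as from compound 1, though not from compound 3. Nothing available explains why these aryl groups give such close numbers.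

The step from compound 1 to compound 4 changes both the substituent and its place on the ring, so 4-chlorophenyl and 3-hydroxyphenyl would be needed to tell those two changes apart. On these data alone, it also remains open whether a methoxy group, an amine or a carboxylic acid in place of the hydroxy group of compound 4 would keep the number in this range.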